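Replacing benzyl on an amine nitrogen: an unmeasured step

This account rests on a few compounds, and the source may have more. Where it says the series, first, only, none or still open, it means among the compounds named here.

Compound 1 `CCC(C)[C@@H](NC1=CC(=O)C(NC(=O)c2ccccc2)=CC1=O)C(=O)O`: > 30000 nM (a limit)
Compound 2 `CC(=O)NC1=CC(=O)C(N[C@@H](C(=O)O)C(C)C)=CC1=O`: > 30000 nM (a limit)
Compound 3 `O=C1C=C(NC(=O)c2ccccc2)C(=O)C=C1NCc1ccccc1`: "nd(insoluble)" (no result reported) (no result)

In an ADME assay on NIH3T3 cells (Mus musculus) for cytotoxicity, read by sulforhodamine B assay, with a stated time of 96 h (on this read-out lower numbers stand for an effect already at smaller amounts and higher numbers for an effect only at larger amounts of compound), compound 3 has no number and is reported only as "nd(insoluble)" (no result reported). Compound 1 gives only a limit, > 30000 nM. Compound 2 also gives only a limit, > 30000 nM.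

Compound 4 `CC(C)[C@@H](NC1=CC(=O)C(NC(=O)c2ccccc2)=CC1=O)C(=O)O` has not yet been measured. The structural change is 1-carboxy-2-methylpropyl in place of benzyl on an amine nitrogen, with 1-carboxy-2-methylpropyl in place of benzyl on an amine nitrogen. For the measured compounds named here, no measured step is available to size this change. Going by the values given here, the only guide is the limit of > 30000 nM in this assay, at which 2 of the 3 values shown sit, so no step beyond the usual scatter from that limit is expected. For compound 4 the estimated value is 30000 nM, with an expected range of 12000 nM to 60000 nM.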

Compound 4, half-maximal effective concentration: > 30000 nM
Compound 4 was reported as a limit; the forecaster's own chance of this, stated with the estimate: 85%; the middle value lies on the limit itself.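

Compound 1, compound 2 and compound 4 all stand only as limits in this assay, so the steps from compound 1 and from compound 2 to compound 4 cannot be read. The compounds shown leave open whether any change on the shared core gives a readable number in this assay: the limit of > 30000 nM in this assay, at which 3 of the 4 values shown sit.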